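Shortening the Pentyl Chain to a Cyclopropyl Ring

The source may hold more compounds than are shown below. What is called first, only, known or untested is meant among the compounds shown, and "the series" means these compounds.

Values in a functional assay (Nicotiana tabacum); a higher number here means a weaker inhibitor, a lower number a stronger inhibitor:
Compound 1 `CCCNc1nc(SC)nc2ncccc12`: 270 nM
Compound 2 `CCCCNc1nc(SC)nc2ncccc12`: 270 nM
Compound 3 `CCCCCNc1nc(SC)nc2ncccc12`: 650 nM

Of these three, compound 3 has the highest number, at 650 nM, so it is the weakest inhibitor measured so far. Compound 4 `CSc1nc(NC2CC2)c2cccnc2n1` keeps the shared core but carries cyclopropyl in place of pentyl on a nitrogen on an aromatic ring.

The closest evidence comes from the straight chains. Growing the chain first gives no change at the digits printed from compound 1 to compound 2 (within the scatter), and growing it again gives a 2.4-fold higher number from compound 2 to compound 3 (0.38 log units; beyond the scatter). Across the whole series, the change is a 2.4-fold higher number from compound 1 to compound 3 (0.38 log units; beyond the scatter). Among the measured compounds shown here, no measured compound carries a ring on that nitrogen, so this comparison is only a rough guide.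

Moving from pentyl to the smaller cyclopropyl should therefore lower the number in this assay, by about the size of these modest steps. The expected change is a 1.9-fold lower number from compound 3 to compound 4 (0.27 log units; within the scatter). For compound 4 the estimated value is 350 nM, with an expected range of 110 nM to 1100 nM.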

Compound 4, half-maximal inhibitory concentration: 4900 nM
For compound 4 the middle estimate is 14-fold (1.15 log units) below the measured one; measured number above the stated range.
By their numbers in this assay, from the lowest: compounds 1 and 2 (each within the scatter of the next); then compound 3; then compound 4.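

On a nitrogen on an aromatic ring, replacing a straight chain with a ring matters more than any change in chain length seen so far: in this assay, cyclopropyl gives a 7.5-fold higher number from compound 3 to compound 4 (0.88 log units; beyond the scatter) and, against the shorter chains, an 18-fold higher number from compound 2 to compound 4 (1.26 log units; beyond the scatter) and an 18-fold higher number from compound 1 to compound 4 (1.26 log units; beyond the scatter) as well. Cyclopropyl has fewer carbons than pentyl, yet compound 4 is the weakest inhibitor of the four, so carbon count alone does not set the number at this position. Nothing available here explains this loss of activity.

Still open, going by these compounds, is whether the loss is specific to the three-membered ring or extends to rings in general. Cyclobutyl, cyclopentyl or a branched chain such as isopropyl on that nitrogen would help to separate these possibilities.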